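Oxime oxygen substituent series: truncation toward methoxy

The source may hold more compounds than are shown below. What is called first, only, known or untested is meant among the compounds shown, and "the series" means these compounds.

Measured so far in an assay on brain (strain Sprague-Dawley) for displacement of a labelled ligand from metabotropic glutamate receptor 5 (Rattus norvegicus), with a stated time of 45 min; on this read-out lower numbers stand for stronger inhibition and higher numbers for weaker inhibition:
compound 1 `Fc1cccc(O/N=C2/C=C(C#Cc3ccccn3)CCC2)n1` gives 9.15 nM
compound 2 `FCCCOCO/N=C1/C=C(C#Cc2ccccn2)CCC1` gives 5.42 nM
compound 3 `FCCOCCO/N=C1/C=C(C#Cc2ccccn2)CCC1` gives 3.8 nM

Compound 3 has the lowest number of the three in this assay; its gap to compound 2 lies within the scatter, while a 2.4-fold lower number from compound 1 to compound 3 (0.38 log units; beyond the scatter) is beyond it. Compound 4 `CO/N=C1/C=C(C#Cc2ccccn2)CCC1` differs from compound 3 by hydrogen in place of (2-fluoroethoxy)methyl on a saturated chain carbon bound to an oxygen on an unsaturated carbon. The measured steps bearing on this position are a 1.7-fold lower number from compound 1 to compound 2 (0.23 log units; within the scatter), a 2.4-fold lower number from compound 1 to compound 3 (0.38 log units; beyond the scatter) and a 1.4-fold lower number from compound 2 to compound 3 (0.15 log units; within the scatter); each swaps one group on the oxime oxygen for another, and none removes the chain altogether, so the truncation is not covered directly. Since three different groups there gave only small to modest movement, a small step is expected, most likely a somewhat higher number. Compound 4 is expected at 5 nM in this assay, with a range of 1.8 nM to 14 nM. This estimate corresponds to a 1.3-fold higher number from compound 3 to compound 4 (0.12 log units; within the scatter).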

Compound 4, inhibition constant: 2.2 nM
Beside the measured number, compound 4's estimate is 2.3-fold (0.36 log units) above it; the measured number falls inside the stated range.
By their numbers in this assay, from the lowest: compounds 4, 3, 2 and 1 (each within the scatter of the next, the first and the last beyond it).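

In this assay the oxime oxygen carries methyl as well as it carries the longer chains: (a 1.7-fold lower number from compound 3 to compound 4 (0.24 log units; within the scatter)) shows that removing (2-fluoroethoxy)methyl costs nothing measurable, so neither that chain nor its fluorine is required here. Methyl also separates from the other two groups, with (a 2.5-fold lower number from compound 2 to compound 4 (0.39 log units; beyond the scatter)) and (a 4.2-fold lower number from compound 1 to compound 4 (0.62 log units; beyond the scatter)), the latter being the widest gap in the series. No measured evidence accounts for these steps.

Going by these compounds, whether an ethyl, a 2-hydroxyethyl or a 2-aminoethyl group on the oxygen would hold this level remains open.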